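Furan-3-yl in place of 1H-pyrazol-1-yl: working notes

This account rests on a few compounds, and the source may have more. Where it says the series, first, only, none or still open, it means among the compounds named here.

Measured in a functional assay on VCaP cells (Homo sapiens) for antiproliferative activity, read by CCK-8 assay, with a stated time of 6 days; a lower number here means a stronger inhibitor, a higher number a weaker inhibitor:
- compound 1 `CCN(c1ccc(C#N)c(Cl)c1)c1cc(-n2cnc3ccccc32)ccc1C`: 8560 nM
- compound 2 `CCN(c1ccc(C#N)c(Cl)c1)c1cc(-c2cccs2)ccc1C`: "not determined" (no result reported)
- compound 3 `CCN(c1ccc(C#N)c(Cl)c1)c1cc(-n2cccn2)ccc1C`: 2340 nM

Of the two numbers available, compound 3 gives the lower, 2340 nM, and compound 1 gives the higher, 8560 nM. Next in line is compound 4 `CCN(c1ccc(C#N)c(Cl)c1)c1cc(-c2ccoc2)ccc1C`, with this change: furan-3-yl in place of 1H-pyrazol-1-yl on an aromatic carbon. The new group, furan-3-yl, replaces 1H-pyrazol-1-yl on an aromatic carbon.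

Going by the values given here, only one measured step bears on this change: a 3.7-fold lower number from compound 1 to compound 3 (0.56 log units; beyond the scatter). It is modest, and it involves a different pair of groups at the same place. Among the compounds with values here, compound 2 adds no guidance, having no result, and no compound carrying furan-3-yl has been measured. The direction in this assay is therefore poorly defined, with a small rise in the number slightly favoured. The expected step is a 1.3-fold higher number from compound 3 to compound 4 (0.11 log units; within the scatter), and it may well prove to lie within the scatter. For compound 4 the estimated value is 3000 nM, with an expected range of 1000 nM to 9000 nM.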

Compound 4, half-maximal inhibitory concentration: 4010 nM
The estimate for compound 4 lay 1.3-fold (0.13 log units) below the measured number; low and high end bracket the measured number.
By their numbers in this assay, from the lowest: compounds 3 and 4 (each within the scatter of the next); then compound 1.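

In this assay, furan-3-yl in place of 1H-pyrazol-1-yl gives a 1.7-fold higher number from compound 3 to compound 4 (0.23 log units; within the scatter), so at this position, on an aromatic carbon para to a methyl group, the data do not separate a five-membered aromatic ring with oxygen from one with two nitrogens. Furan-3-yl in place of 1H-benzimidazol-1-yl gives a 2.1-fold lower number from compound 1 to compound 4 (0.33 log units; beyond the scatter), so both five-membered rings measured so far stand on the lower side of compound 1, and nitrogen in the ring is not needed for that. No measurement available here offers an explanation for either step.

Where compound 2 falls remains open, since its entry has no result. Going by these compounds, how an amine or a carboxylic acid at this place would compare with these rings also remains open.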